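The source may report more compounds than this note shows. Statements on the series, on what has been measured and on what is new or still open speak of the compounds shown alone.

Working notes on the series. a functional assay on cells (Lymphocyte, Homo sapiens) for inhibition, read by flow cytometry, using a membrane potential dye, with a stated time of 16 h, tested at 250 nM (a higher number here means a stronger effect of the compound at the concentration tested, a lower number a weaker effect), is the only read-out in hand. Compound 1, `CCCCCCCCCCc1c(C)c(N(C)C)nc(C)c1O`, gives 78%. Compound 2, `Cc1c(N(C)C)nc(CCCCCCCCCCO)c(O)c1C`, gives 36%. Compound 3, `CCCCCCCCCCc1nc(N(C)C)c(C)c(C)c1O`, gives 82%; this number stands beyond the scatter above compound 2 and within the scatter of compound 1, so compound 3 and compound 1 are not told apart by this assay.

Within the data shown here, the one step between compounds differing in a single place is a number 46 percentage points higher from compound 2 to compound 3 (beyond the scatter), hydrogen in place of hydroxy on a saturated chain carbon, ten or more bonds along the chain from an aromatic carbon.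

Compound 4 is `CCCCCCCCCCCCCCCCCCCc1nc(N(C)C)c(C)c(C)c1O`. It differs from compound 3 as follows: nonyl in place of hydrogen on a saturated chain carbon, ten or more bonds along the chain from an aromatic carbon. Among the measured compounds shown here, the place is the same one at which the step from compound 2 to compound 3 was measured, but that step concerned a hydroxy leaving, not a nonyl entering; no measured pair shows a nonyl in place of hydrogen, or any other change in chain length with the rest held the same. The step from compound 2 to compound 3 therefore gives no direction for this change. With compound 3 already high in this assay, the step expected is a number 10 percentage points lower from compound 3 to compound 4 (within the scatter), small, with a fall weighed slightly more than a rise. Compound 4 is expected to give 72%, between 40% and 95%.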

Compound 4, a percentage reported as activity, at one concentration (the size of the read-out at that concentration, not a potency): 44%
Compound 4: middle estimate off by 28 percentage points, on the high side; low and high end bracket the measured number.
By their numbers in this assay, from the lowest: compounds 2 and 4 (each within the scatter of the next); then compounds 1 and 3 (each within the scatter of the next).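

At this place in this assay, the measured pairs now include a change that adds only carbon: nonyl in place of hydrogen gives a number 38 percentage points lower from compound 3 to compound 4 (beyond the scatter) and shows that the chain cannot be lengthened by this amount without a large loss at the concentration tested. Nonyl in place of hydroxy gives a number 8 percentage points higher from compound 2 to compound 4 (within the scatter) and so does not tell compound 2 and compound 4 apart, which leaves compound 3 beyond the scatter above both of the chains changed at this place. No measurement in hand bears on why the number falls with the nonyl group.

Open, as far as these compounds go, is how the number runs with chain length between compound 3 and compound 4, and whether a shorter chain would hold it as high as compound 3 does at 82% or not. Also open, from the compounds shown here alone, are whether an amine or a carboxylic acid at the chain end would behave like the hydroxy of compound 2, and whether the same lengthening on the core of compound 1 would give a step of the same size.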